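Swapping Methylphenyl for Chlorophenyl: Expected Cytotoxicity

This account rests on a few compounds, and the source may have more. Where it says the series, first, only, none or still open, it means among the compounds named here.

Three compounds share one core and differ only in the aromatic group on an aromatic nitrogen. Compound 1 `O=c1[nH]cc(S(=O)(=O)Nc2ccccc2-c2cn(-c3ccccc3)nn2)c(=O)[nH]1` carries a plain phenyl there. In an ADME assay on GES1 cells (Homo sapiens) for cytotoxicity, read by MTT assay, with a stated time of 24 h (on this read-out lower numbers stand for higher toxicity in this test and higher numbers for lower toxicity in this test), compound 1 gives > 100000 nM, which is a limit of the assay rather than a number (the limit of > 100000 nM in this assay, at which 1 of the 3 values shown sits). Compound 2 `Cc1cccc(-n2cc(-c3ccccc3NS(=O)(=O)c3c[nH]c(=O)[nH]c3=O)nn2)c1` carries 3-methylphenyl and gives 23700 nM in this assay. Compound 3 `O=c1[nH]cc(S(=O)(=O)Nc2ccccc2-c2cn(-c3ccccc3Cl)nn2)c(=O)[nH]1` carries 2-chlorophenyl and gives 20800 nM in this assay. Of the two plain numbers, compound 2 sits highest, with compound 3 nearest at a 1.1-fold lower number from compound 2 to compound 3 (0.06 log units; within the scatter), a gap within the scatter. Both substituted compounds moved clear of compound 1: methyl in place of hydrogen gave an at least 4.2-fold lower number from compound 1 to compound 2 (0.62 log units; beyond the scatter), chloro in place of hydrogen gave an at least 4.8-fold lower number from compound 1 to compound 3 (0.68 log units; beyond the scatter).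

Compound 4 `O=c1[nH]cc(S(=O)(=O)Nc2ccccc2-c2cn(-c3ccc(Cl)cc3)nn2)c(=O)[nH]1` has not yet been measured. It differs from compound 2 as follows: 4-chlorophenyl in place of 3-methylphenyl on an aromatic nitrogen. The step from compound 2 to compound 3, a 1.1-fold lower number from compound 2 to compound 3 (0.06 log units; within the scatter), bears most directly on this change, as it also put a chlorophenyl in place of 3-methylphenyl and stayed within the scatter. Since both substituted phenyls lowered the number from compound 1, an at least 4.2-fold lower number from compound 1 to compound 2 (0.62 log units; beyond the scatter) and an at least 4.8-fold lower number from compound 1 to compound 3 (0.68 log units; beyond the scatter), compound 4 is not expected to return to the limit of compound 1. The expected step is therefore none beyond the scatter: a 1.2-fold lower number from compound 2 to compound 4 (0.07 log units; within the scatter). For compound 4 the estimate is 20000 nM, with a range from 8000 nM to 50000 nM.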

Compound 4, half-maximal cytotoxic concentration: 26700 nM
For compound 4 the middle estimate is 1.3-fold (0.13 log units) below the measured one; low and high end bracket the measured number.
By their numbers in this assay, from the lowest: compounds 3, 2 and 4 (each within the scatter of the next). At a limit, above all of these: compound 1.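

Replacing the chlorine position on the ring, with 4-chlorophenyl in place of 2-chlorophenyl, gives a 1.3-fold higher number from compound 3 to compound 4 (0.11 log units; within the scatter), and exchanging 3-methylphenyl for 4-chlorophenyl gives a 1.1-fold higher number from compound 2 to compound 4 (0.05 log units; within the scatter), so in this assay neither the kind of substituent nor its place on this phenyl separates these three compounds. A third substituted phenyl now stands apart from the plain phenyl, with an at least 3.7-fold lower number from compound 1 to compound 4 (0.57 log units; beyond the scatter), so this separation is shared by every substituted compound shown and does not depend on a single group or ring position. The true size of that step stays unknown, as compound 1 is held at a limit of the assay and not at a number: the limit of > 100000 nM in this assay, at which 1 of the 4 values shown sits.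

The substituents shown on this phenyl are only methyl and chloro, so it remains open whether an amine, a carboxylic acid or a methoxy group there would stay with compounds 2, 3 and 4 or move away from them. Also open, going by these compounds, is what would happen if a longer alkyl chain took the place of the whole phenyl on the aromatic nitrogen.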